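Hydroxyalkyl chain length at the ring nitrogen: compound 3

This account rests on a few compounds, and the source may have more. Where it says the series, first, only, none or still open, it means among the compounds named here.

The series is built on the core of compound 1 `c1ccc2cc(-c3noc([C@@H]4CCCCN4)n3)ccc2c1`, the parent with hydrogen on the amine nitrogen in the ring. In an assay on HepG2 cells for antagonist activity at Bile acid receptor (Homo sapiens), read by a luciferase reporter (a lower number here means a stronger inhibitor, a higher number a weaker inhibitor), compound 1 gives 127 nM. Compound 2 `OCCCN1CCCC[C@H]1c1nc(-c2ccc3ccccc3c2)no1` carries a 3-hydroxypropyl chain on that nitrogen, and in this assay compound 2 gives 27000 nM. For the measured compounds named here, the step of a 210-fold higher number from compound 1 to compound 2 (2.33 log units; beyond the scatter) is the only one measured so far, and compound 2 holds the highest number of the two, with compound 1 as its only neighbour.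

Compound 3 `OCCCCN1CCCC[C@H]1c1nc(-c2ccc3ccccc3c2)no1` differs from compound 2 by hydroxymethyl in place of hydroxy on a saturated chain carbon, three bonds along the chain from an amine nitrogen in a ring, so the chain is lengthened by one link while the donor and acceptor count stays the same. Going by the values given here, no measured pair shows what a single extra chain carbon does here; the one known step concerns attaching the whole chain, and it was large. With nothing to separate the effect of chain length from that of the chain itself, no shift beyond the scatter is expected in this assay, so the expected step is no change at the digits printed from compound 2 to compound 3 (within the scatter). The estimate for compound 3 is 27000 nM, within 7000 nM to 90000 nM.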

Compound 3, half-maximal inhibitory concentration: 7000 nM
Compound 3: the middle estimate sits 3.9-fold (0.59 log units) above what was measured, and the stated range covers the measured number.
By their numbers in this assay, from the lowest: compound 1; then compound 3; then compound 2.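

In this assay, the chain length at the ring nitrogen proves to matter on its own: going from 3-hydroxypropyl to 4-hydroxybutyl gives a 3.9-fold lower number from compound 2 to compound 3 (0.59 log units; beyond the scatter) and so separates the effect of one extra chain carbon from that of attaching a chain at all. That recovery remains partial, since the 4-hydroxybutyl chain still leaves a 55-fold higher number from compound 1 to compound 3 (1.74 log units; beyond the scatter) and the hydrogen-bearing parent keeps the lowest number of the three. Two chain lengths give a direction rather than a trend, so nothing here shows whether the number would keep falling with a longer chain such as 5-hydroxypentyl or would turn back up.

Also open, going by these compounds, is what the terminal hydroxy contributes compared with the carbon chain, a question that a plain butyl group, or a carboxylic acid or an amine at the chain end, could address. No measurement at hand bears on the reason for either step.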